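Cytotoxicity in HeLa Cells: From Compound 2 to Compound 4

The source may hold more compounds than are shown below. What is called first, only, known or untested is meant among the compounds shown, and "the series" means these compounds.

Compound 1, `CC(C)CCn1c(Cn2c(=O)n(C3CC3)c3ccncc32)nc2nc(Cl)ccc21`: > 50000 nM
Compound 2, `N#CCCCn1c(Cn2c(=O)n(-c3ccncc3F)c3ccncc32)cc2cc(Cl)ccc21`: > 50000 nM
Compound 3, `CS(=O)(=O)CCCn1c(Cn2c(=O)[nH]c3ccncc32)cc2cc(Cl)ccc21`: > 50000 nM

All three were tested in an ADME assay on HeLa cells (Homo sapiens) for cytotoxicity, read by ATP content, with a stated time of 3 days; a lower number here means that less compound is tolerated, a higher number that more compound is tolerated. For compound 2 the result > 50000 nM is a limit of the assay, not a number. The same picture holds across the set, given (the limit of > 50000 nM in this assay, at which 3 of the 3 values shown sit), so compound 2 cannot be ranked against compound 1 or compound 3; each sits at the limit.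

Compound 4, `COc1ccc(-n2c(=O)n(Cc3cc4cc(Cl)ccc4n3CCCC#N)c3cnccc32)cc1C`, has not yet been measured in this assay. Its change from compound 2 is 4-methoxy-3-methylphenyl in place of 3-fluoropyridin-4-yl on an aromatic nitrogen. For the measured compounds named here, no step between two measured compounds is known here, so no size of step can be read from the data. The expected step from compound 2 to compound 4 is a number no higher from compound 2 to compound 4 (the limit leaves the size open), that is, none beyond the scatter. Compound 4 is therefore estimated at 50000 nM, with a range from 20000 nM to 100000 nM.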

Compound 4, half-maximal cytotoxic concentration: > 50000 nM
Compound 4: a limit, no number; the forecaster's own chance of this, stated with the estimate: 75%; the middle value sits exactly at the limit.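

No step from compound 2 to compound 4 can be read, because both sit at a limit of the assay, not at a number: the limit of > 50000 nM in this assay, at which 4 of the 4 values shown sit.

The compounds shown leave open whether 4-methoxy-3-methylphenyl and 3-fluoropyridin-4-yl differ at all in this assay.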